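The source may hold more compounds than are shown below. What is called first, only, known or untested is meant among the compounds shown, and "the series" means these compounds.

Among the compounds with values here, in an ADME assay on L132 cells (Homo sapiens) for cytotoxicity, read by MTT assay, with a stated time of 48 h (a lower number here means a stronger inhibitor, a higher number a weaker inhibitor), none of the three measured members reaches a number; every one of them stops at a limit of the assay. Compound 1 `C/C(=C\CC/C(C)=C/CC[C@@H]1[C@@]2(C)CCC(=O)C(C)(C)[C@H]2CC[C@@]1(C)O)CC/C=C(\C)C(=O)OCc1cn(-c2ccc(F)cc2)nn1` gives > 150000 nM in this assay, which is a limit. Compound 2 `COc1ccccc1-n1cc(COC(=O)/C(C)=C/CC/C(C)=C/CC/C(C)=C/CC[C@@H]2[C@@]3(C)CCC(=O)C(C)(C)[C@H]3CC[C@@]2(C)O)nn1` gives > 150000 nM in this assay, again a limit. Compound 3 `C/C(=C\CC/C(C)=C/CC[C@@H]1[C@@]2(C)CCC(=O)C(C)(C)[C@H]2CC[C@@]1(C)O)CC/C=C(\C)C(=O)OCc1cn(-c2cccc(C)c2)nn1` gives > 150000 nM in this assay, also a limit. For this reason the step that the two limits leave unreadable from compound 1 to compound 2, the step that the two limits leave unreadable from compound 1 to compound 3 and the step that the two limits leave unreadable from compound 2 to compound 3 cannot be given a size; what the series shows so far is only (the limit of > 150000 nM in this assay, at which 3 of the 3 values shown sit).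

Compound 4 `C/C(=C\CC/C(C)=C/CC[C@@H]1[C@@]2(C)CCC(=O)C(C)(C)[C@H]2CC[C@@]1(C)O)CC/C=C(\C)C(=O)OCc1cn(-c2ccccc2Cl)nn1` is the next member to go into this assay. It differs from compound 2 by chloro in place of methoxy on an aromatic carbon. Within the data shown here, no measured step offers a readable size that would bear on a change of this kind, since each of them joins two values that stand at the limit. Among the measured compounds shown here, the expectation is therefore that compound 4 will again stand at the limit, because the only guide is the limit of > 150000 nM in this assay, at which 3 of the 3 values shown sit. The expected step that the limit leaves unreadable from compound 2 to compound 4 is one that the scatter would cover. Compound 4 is estimated at 200000 nM, within 100000 nM to 600000 nM.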

Compound 4, half-maximal inhibitory concentration: > 150000 nM
Compound 4: a limit, no number; the forecaster's own chance of this, stated with the estimate: 85%; the middle value lies beyond the limit too.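

In this assay compound 4 gives > 150000 nM, which is a limit. Its steps to compound 1, compound 2 and compound 3 therefore cannot be read, and no size can be given for any of them. Whether the four compounds differ at all in this assay, and how far beyond the limit each one lies, stays open: the limit of > 150000 nM in this assay, at which 4 of the 4 values shown sit.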